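The source may hold more compounds than are shown below. What is called first, only, known or untested is meant among the compounds shown, and "the series" means these compounds.

Measured compounds in an ADME assay on microsomes from liver (Homo sapiens) for metabolic stability, tested at 2.5 uM; a higher number here means faster removal of the compound, a lower number slower removal:
compound 1, `Clc1ccc(-c2ccc(Cn3nnc4ccccc43)cn2)cc1`, 0.2 mL/min/g
compound 2, `Fc1cc(Cn2nnc3c(Br)cccc32)ccc1Cl`, 0.4 mL/min/g
compound 3, `Brc1cccc2c1nnn2CC1CC1`, 1.3 mL/min/g

In this assay compound 1 gives 0.2 mL/min/g and compound 2 gives 0.4 mL/min/g, while compound 3 gives 1.3 mL/min/g, the highest of the three numbers. The gap from compound 3 to compound 2 and the gap from compound 3 to compound 1 both lie beyond the usual scatter of repeated measurements, so compound 3 is the one removed fastest among the three.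

Compound 4, `CCCn1nnc2c(Br)cccc21`, has not yet been measured. Compared with compound 3 the change is ethyl in place of cyclopropyl on a saturated chain carbon bound to an aromatic nitrogen. Among the measured compounds shown here, none of the measured pairs shares this change in one place, so there is no measured step of this kind to lean on; the expectation rests on the value of compound 3 alone and on the small size of the change. The step expected from compound 3 to compound 4 in this assay is a 1.2-fold higher number from compound 3 to compound 4 (0.09 log units; within the scatter), a modest move upward that may well stay within the scatter. Compound 4 is therefore estimated at 1.6 mL/min/g, with a range from 0.7 mL/min/g to 3.5 mL/min/g.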

Compound 4, intrinsic clearance in a liver preparation (reported as CLH), per the amount of preparation that the assay uses: 4.7 mL/min/g
Compound 4: middle estimate off by 2.9-fold (0.47 log units), on the low side; measured number outside the range, above it.
By their numbers in this assay, from the lowest: compounds 1 and 2 (each within the scatter of the next); then compound 3; then compound 4.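

Among the compounds shown here, replacing cyclopropyl with ethyl, which read one bond further out is cyclopropylmethyl to propyl, gives the first single-place step: in this assay the open chain is removed faster (a 3.6-fold higher number from compound 3 to compound 4 (0.56 log units; beyond the scatter)), so even this small change on a saturated chain carbon bound to an aromatic nitrogen moves the read-out beyond the scatter. The change takes away the three-membered ring of carbon only, while the counts of hydrogen-bond donors and acceptors and the net charge stay the same, so the step comes without any difference in those counts. No measured evidence shown here accounts for the size or direction of this step.

With only one ring and one open chain to compare on this core, the compounds shown cannot separate the loss of the ring from the nature of the chain that replaces it. From the compounds shown here alone, it remains open how a longer chain such as butyl, a cyclobutyl ring, or a chain ending in an amine or a carboxylic acid would fare at this place, and whether the same change would give a similar step on the core of compound 1.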